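The compounds below may be only part of what the source reports. "The series", "measured", "known", "first", "only" and "open" are said of these compounds alone.

Compound 1 `O=C(O)c1ccc(-c2cnc(C(=O)CCc3ccc(-c4ccccc4)cc3)o2)cn1` is an inhibitor of fatty-acid amide hydrolase; in an assay for inhibition of Fatty-acid amide hydrolase 1 (Rattus norvegicus) (a lower number here means a stronger inhibitor, a higher number a weaker inhibitor), compound 1 gives 44 nM. Compound 2 `O=C(O)c1cccc(-c2cnc(C(=O)CCc3ccc(-c4ccc(CN5CCCCC5)cc4)cc3)o2)n1` sits level with it, since in this assay compound 2 gives 44 nM, a gap that lies within the scatter of repeated measurements. Compound 3 `CSc1cnc(C(=O)CCc2ccc(-c3ccccc3)cc2)o1` has not yet been measured. It differs from compound 1 in one place: methylsulfanyl in place of 6-carboxypyridin-3-yl on an aromatic carbon. For the measured compounds named here, no measured pair shows a step of this kind, so the expectation rests on the size of the group that leaves. A sizeable loss of potency is expected, with the step of a 6.8-fold higher number from compound 1 to compound 3 (0.83 log units; beyond the scatter). For compound 3 the expected value is 300 nM, within a range from 80 nM to 1500 nM.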

Compound 3, inhibition constant: 3 nM
Estimate against measurement, compound 3: 100-fold (2.00 log units) above; the measured number lies below the stated range.
By their numbers in this assay, from the lowest: compound 3; then compounds 1 and 2 (each within the scatter of the next).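

At this position, on an aromatic carbon next to the ring oxygen, a large ring-bearing group is not required for potency: in this assay, replacing 6-carboxypyridin-3-yl with methylsulfanyl gives a 15-fold lower number from compound 1 to compound 3 (1.17 log units; beyond the scatter). Both earlier compounds carry a carboxylic acid on a six-membered aromatic ring here, so they could not show how a small group without a ring behaves. No measurement shown explains the gain.

The compounds shown leave open whether the gain comes from losing the ring or from gaining the sulfur. A methoxy group, an ethyl group or an unsubstituted pyridine ring on this carbon would be needed to separate the two.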